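A Double Bond Turned in an Inactive Series

The compounds below may be only part of what the source reports. "The series", "measured", "known", "first", "only" and "open" are said of these compounds alone.

Compound 1 `CCOC(=O)C1=C(C)NC(=S)NC1c1cccc(OC/C=C\COc2cccc(C3NC(=S)NC(C)=C3C(=O)OCC)c2)c1`, compound 2 `COC(=O)[C@@H]1CCCN1C(=O)C1=C(C)NC(=S)NC1c1cccc(OCCCOc2cccc(C3NC(=S)NC(C)=C3C(=O)N3CCC[C@H]3C(=O)OC)c2)c1` and compound 3 `COC(=O)[C@@H]1CCCN1C(=O)C1=C(C)NC(=S)NC1c1cccc(OC/C=C\COc2cccc(C3NC(=S)NC(C)=C3C(=O)N3CCC[C@H]3C(=O)OC)c2)c1` have all been tested in a functional assay on HT-29 cells (Homo sapiens) for cytotoxicity, read by MTT assay, with a stated time of 48 h; on this read-out higher numbers stand for weaker inhibition and lower numbers for stronger inhibition.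

Compound 1 gives > 200 ug/mL, which is a limit of the assay and not a number. Compound 2 gives > 200 ug/mL, again a limit. Compound 3 gives > 200 ug/mL, also a limit, so it has no exact place on the scale. Taken together, the results show (the limit of > 200 ug/mL in this assay, at which 3 of the 3 values shown sit).

Compound 4 `COC(=O)[C@@H]1CCCN1C(=O)C1=C(C)NC(=S)NC1c1cccc(OC/C=C/COc2cccc(C3NC(=S)NC(C)=C3C(=O)N3CCC[C@H]3C(=O)OC)c2)c1` is a close relative of compound 3: the two compounds have the same atoms and bonds; at least one stereo element is drawn with a configuration in one of them and without one in the other: 1 of 5 stereo elements differ; a double bond is drawn Z in compound 3 and E in compound 4. Nothing leaves and nothing enters, and only the drawing of the double bond changes, from Z in compound 3 to E in compound 4.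

For the measured compounds named here, no tested pair shows what such a change does in this assay. The expectation is therefore no step beyond the scatter, and a result that again reads only as a limit is the likeliest outcome. The expected step is a number no higher from compound 3 to compound 4 (the limit leaves the size open), resting on the limit of compound 3 at > 200 ug/mL. The estimate for compound 4 is 200 ug/mL, with an expected range from 100 ug/mL to 300 ug/mL.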

Compound 4, half-maximal inhibitory concentration: > 200 ug/mL
Compound 4: only a limit was reported; the forecaster's own chance of this, stated with the estimate: 85%; the middle value lies on the limit itself.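

In this assay compound 4 gives > 200 ug/mL, which is a limit of the assay and not a number. Compound 3 also sits at a limit, so no step can be read between compound 3 and compound 4: the limit of > 200 ug/mL in this assay, at which 4 of the 4 values shown sit.

The compounds shown leave open whether turning the double bond from Z to E changes cytotoxicity at all, and where any of these compounds would fall on the scale.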